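Chloro in Place of Methoxy on a Shared Core

The compounds below may be only part of what the source reports. "The series", "measured", "known", "first", "only" and "open" are said of these compounds alone.

Measured in a functional assay on L1210 cells (Mus musculus) for cytotoxicity, with a stated time of 48 h; on this read-out higher numbers stand for weaker inhibition and lower numbers for stronger inhibition:
compound 1 `Cc1ccc(/C=C2\CCC/C(=C\c3cccc([N+](=O)[O-])c3)C2=O)cc1` — 41800 nM
compound 2 `O=C1CCCC/C1=C\c1ccccc1[N+](=O)[O-]` — 23800 nM
compound 3 `COc1ccc(/C=C2\CCC/C(=C\c3ccccc3[N+](=O)[O-])C2=O)cc1` — 42400 nM

All three numbers lie within the usual scatter of one another, so none of these compounds can be set apart as stronger or weaker. Compound 3 carries the nominally highest number, yet compound 1 and compound 2 both fall within the scatter of it. Compound 4 `O=C1/C(=C/c2ccc(Cl)cc2)CCC/C1=C\c1ccccc1[N+](=O)[O-]` has not yet been measured; it differs from compound 3 in one place: chloro in place of methoxy on an aromatic carbon. No change from one measured compound to another in this series has exceeded the scatter, and the swap of methoxy for chloro gives no ground to expect otherwise. Compound 4 is therefore expected near 40000 nM, between 18000 nM and 90000 nM. The step expected is a 1.1-fold lower number from compound 3 to compound 4 (0.03 log units; within the scatter), within the scatter.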

Compound 4, half-maximal inhibitory concentration: 9380 nM
Estimate against measurement, compound 4: 4.3-fold (0.63 log units) above; the whole stated range lies above it.
By their numbers in this assay, from the lowest: compound 4; then compounds 2, 1 and 3 (each within the scatter of the next).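

For the compounds shown here, the change from 4-methoxyphenyl to 4-chlorophenyl gives a 4.5-fold lower number from compound 3 to compound 4 (0.66 log units; beyond the scatter) in this assay, the only step here that lies beyond the scatter. It shows that the group on this aromatic carbon, para to a large group, can shift the number, and that a chloro suits this read-out better than a methoxy. Nothing at hand bears on why the number moved.

From the compounds shown here alone, whether this gain is specific to chloro remains open, as one swap cannot separate it from other groups. Fluoro, bromo or an amine at the same place would test this.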